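The compounds below may be only part of what the source reports. "The series", "measured", "known", "first", "only" and "open" are said of these compounds alone.

Compound 1 `Cc1cc(-c2ccccc2)cc(C)c1Nc1ccnc(Nc2ccc(C#N)cc2)n1` gives 4170 nM in an ADME assay on MT4 cells (Homo sapiens) for cytotoxicity, read by MTT assay, with a stated time of 4 days; on this read-out lower numbers stand for higher toxicity in this test and higher numbers for lower toxicity in this test.
Compound 2 `Cc1cc(-c2ccccc2Cl)cc(C)c1Nc1ccnc(Nc2ccc(C#N)cc2)n1` gives 3990 nM in this assay.
Compound 3 `Cc1ccccc1-c1cc(C)c(Nc2ccnc(Nc3ccc(C#N)cc3)n2)c(C)c1` gives 3820 nM in this assay.

Compound 3 sits with the other two numbers rather than apart from them: the step of a 1.1-fold lower number from compound 1 to compound 3 (0.04 log units; within the scatter) and the step of a 1.0-fold lower number from compound 2 to compound 3 (0.02 log units; within the scatter) both fall within the scatter, so the three measured compounds cannot be told apart on this read-out.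

Compound 4 `Cc1ccc(-c2cc(C)c(Nc3ccnc(Nc4ccc(C#N)cc4)n3)c(C)c2)cc1` is the next member of the series. It differs from compound 3 in one place: 4-methylphenyl in place of 2-methylphenyl on an aromatic carbon. The change keeps every atom and only moves the methyl group on the pendant ring.

Each of the measured steps also changed the substitution on that same pendant ring, and none of them moved the number beyond the scatter: a 1.0-fold lower number from compound 1 to compound 2 (0.02 log units; within the scatter), a 1.1-fold lower number from compound 1 to compound 3 (0.04 log units; within the scatter) and a 1.0-fold lower number from compound 2 to compound 3 (0.02 log units; within the scatter). Given that all three variations at this position left this assay unchanged within the scatter, the rearrangement of the methyl group is expected to do the same, and the expected step of a 1.0-fold higher number from compound 3 to compound 4 (0.01 log units; within the scatter) is none beyond the scatter.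

For compound 4 the estimate in this assay is therefore 3900 nM, with a range from 2300 nM to 6500 nM.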

Compound 4, half-maximal cytotoxic concentration: 5570 nM
Compound 4: middle estimate off by 1.4-fold (0.15 log units), on the low side; the range from low to high includes it.
By their numbers in this assay, from the lowest: compounds 3, 2, 1 and 4 (each within the scatter of the next).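

In this assay, for the compounds shown here, the move from 2-methylphenyl to 4-methylphenyl is a 1.5-fold higher number from compound 3 to compound 4 (0.16 log units; within the scatter) and so adds something the earlier compounds could not show: where the methyl group sits on the pendant ring, and not only whether it is there, leaves this read-out unresolved. The same holds for 4-methylphenyl against 2-chlorophenyl, with a 1.4-fold higher number from compound 2 to compound 4 (0.14 log units; within the scatter) and for 4-methylphenyl against the unsubstituted phenyl, with a 1.3-fold higher number from compound 1 to compound 4 (0.13 log units; within the scatter) as the step. Every pair among the four compounds now lies within the scatter, so neither the kind of small group on this ring nor its place on it has separated any compound from the others in this assay.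

All the variation shown is limited to a methyl group or a chloro group on the pendant ring, so it remains open whether this number would stay put with an amine, a carboxylic acid or a longer chain there. The compounds also leave open whether the shared core, which is the same in all four, has any bearing on this read-out. No evidence is available that would account for these numbers.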